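The compounds below may be only part of what the source reports. "The series", "measured", "known", "first", "only" and "open" are said of these compounds alone.

Measured in a functional assay on HCT-116 cells (Homo sapiens) for antiproliferative activity, read by MTT assay, with a stated time of 72 h; a lower number here means a stronger inhibitor, a higher number a weaker inhibitor:
Compound 1, `O=C(CCc1cccc2c1B(O)OC2)Nc1ccc(F)cc1`: 650 nM
Compound 2, `O=C(CCc1cccc2c1B(O)OC2)Nc1cccc(Br)c1`: 1400 nM

Among the measured compounds shown here, compound 2 gives the higher of these two numbers; the only measured step available is a 2.2-fold higher number from compound 1 to compound 2 (0.33 log units; beyond the scatter), a swap of the group on the amide-type nitrogen. Compound 3, `N#Cc1cccc(-c2cccc(NC(=O)CCc3cccc4c3B(O)OC4)c2)c1`, has not yet been measured. It differs from compound 2 as follows: 3-cyanophenyl in place of bromo on an aromatic carbon. The measured step bears on this only loosely: it too altered the part of the molecule attached to the amide-type nitrogen, and it was modest in size. Nothing measured here involves a group as large as 3-cyanophenyl, so the direction is open. The step from compound 2 to compound 3 is therefore expected to be small, a 1.4-fold lower number from compound 2 to compound 3 (0.15 log units; within the scatter), with wide uncertainty either way. For compound 3 the estimate in this assay is 1000 nM, with a likely range from 300 nM to 3500 nM.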

Compound 3, half-maximal inhibitory concentration: 140 nM
Compound 3: middle estimate off by 7.1-fold (0.85 log units), on the high side, outside the stated range (below it).
By their numbers in this assay, from the lowest: compound 3; then compound 1; then compound 2.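

In this assay, replacing bromo with 3-cyanophenyl on this aromatic carbon gives a 10-fold lower number from compound 2 to compound 3 (1.00 log units; beyond the scatter) and so makes a much larger difference than the earlier swap of one halogen-bearing phenyl for another, which gave a 2.2-fold higher number from compound 1 to compound 2 (0.33 log units; beyond the scatter). This position, meta to a large group, therefore accepts a far bigger group of 8 heavy atoms in place of 1, and the number falls rather than rises. Nothing shown here accounts for this gain.

The compounds shown leave open whether the added aromatic ring alone carries the step or the nitrile also contributes. A plain phenyl at this carbon, or a phenyl carrying an amine or a carboxylic acid in place of the nitrile, would help separate those two parts.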